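Dropping one methoxy group from compound 1

The source may report more compounds than this note shows. Statements on the series, on what has been measured and on what is new or still open speak of the compounds shown alone.

Measured so far:
Compound 1, `COc1cc(-c2cc(/C=C/C(=O)c3ccc(N)cc3)[nH]n2)cc(OC)c1OC`, gives 106%.
Compound 2, `COc1ccc(C(=O)/C=C/c2cc(-c3cc(OC)c(OC)c(OC)c3)n[nH]2)cc1OC`, gives 86%.
Compound 3, `COc1ccc(C(=O)/C=C/c2cc(-c3cc(OC)c(OC)c(OC)c3)n[nH]2)cc1`, gives 92%.

In a functional assay on SK-MEL-2 cells (Homo sapiens) for cytotoxicity, read by sulforhodamine B assay, with a stated time of 48 h, tested at 0.01 uM (on this read-out lower numbers stand for a stronger effect and higher numbers for a weaker effect at the one concentration tested), compound 1 stands highest of the three. The cores of compound 2 and compound 1 differ as 4-aminophenyl in place of 3,4-dimethoxyphenyl on a carbonyl carbon, and the step is a number 20 percentage points lower from compound 1 to compound 2 (beyond the scatter). Going to compound 3 gives a number 14 percentage points lower from compound 1 to compound 3 (beyond the scatter). Within the series carrying the 3,4-dimethoxyphenyl group, the change hydrogen in place of methoxy on an aromatic carbon made the step of a number 6 percentage points higher from compound 2 to compound 3 (within the scatter).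

Compound 4, `COc1ccc(-c2cc(/C=C/C(=O)c3ccc(N)cc3)[nH]n2)cc1OC`, is unmeasured. It differs from compound 1 by hydrogen in place of methoxy on an aromatic carbon, the same kind of change as that from compound 2 to compound 3, though here the place is also meta to a methoxy group. Because that earlier step was a number 6 percentage points higher from compound 2 to compound 3 (within the scatter), a similarly small step is expected here, a number 2 percentage points lower from compound 1 to compound 4 (within the scatter). Compound 4 is therefore estimated at 104%, between 90% and 118%.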

Compound 4, a percentage reported as activity, at one concentration (the size of the read-out at that concentration, not a potency): 103%
Estimate against measurement, compound 4: 1 percentage points above; measured number inside the range.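

In this assay, hydrogen in place of methoxy on an aromatic carbon of the core of compound 1 gave a number 3 percentage points lower from compound 1 to compound 4 (within the scatter). Set beside the same change on the other core, this step does not differ from the earlier one: the same change on two cores in this assay, a number 6 percentage points higher (within the scatter) from compound 2 to compound 3 and a number 3 percentage points lower (within the scatter) from compound 1 to compound 4, 9 percentage points apart, within the scatter of two such steps. This shows that the change stayed within the scatter on both cores at the one concentration tested, but it rests on two pairs and does not show how the change would behave on any other core or at any other concentration.

The compounds shown leave open whether a different group at this place, such as chlorine, hydroxyl or a longer alkoxy chain like ethoxy, would give a larger step. They also leave open how the change would behave on a core carrying a carboxylic acid in place of the amino group.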